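The source may report more compounds than this note shows. Statements on the series, on what has been measured and on what is new or still open speak of the compounds shown alone.

Compound 1 `COc1ccc(OC)c(/C=N/NC(=O)c2ccc(-c3cccc(Cl)c3)nc2C)c1`: 188 ug/mL
Compound 2 `COc1ccc(/C=N/NC(=O)c2ccc(-c3cccc(Cl)c3)nc2C)cc1`: 500 ug/mL
Compound 3 `COc1ccc(/C=N/NC(=O)c2ccc(-c3ccc(Cl)cc3)nc2C)cc1`: 500 ug/mL

Three hydrazone amides were measured in an ADME assay on WI-38 cells (Homo sapiens) for cytotoxicity, read by colorimetric assay and crystal violet staining, with a stated time of 24 h; a lower number here means a stronger inhibitor, a higher number a weaker inhibitor. Compound 1 gives the lowest of the three numbers; its nearest neighbour, compound 2, gives a value beyond the scatter above it, and compound 3 stands at the same distance. How the core of compound 1 differs from that of compound 2 is not broken down here. From compound 2 to compound 3 the change is 4-chlorophenyl in place of 3-chlorophenyl on an aromatic carbon, and the step is no change at the digits printed from compound 2 to compound 3 (within the scatter). Compound 4 `COc1ccc(OC)c(/C=N/NC(=O)c2ccc(-c3ccc(Cl)cc3)nc2C)c1` is not yet measured; it arises from compound 1 by 4-chlorophenyl in place of 3-chlorophenyl on an aromatic carbon, the same change at the same place. Because the step of no change at the digits printed from compound 2 to compound 3 (within the scatter) was flat, the step of a 1.0-fold higher number from compound 1 to compound 4 (0.00 log units; within the scatter) is expected to be flat as well, so compound 4 is estimated at 190 ug/mL, with a range from 95 ug/mL to 400 ug/mL.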

Compound 4, half-maximal inhibitory concentration: 500 ug/mL
The estimate for compound 4 lay 2.6-fold (0.42 log units) below the measured number; measured number outside the range, above it.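

In this assay, 4-chlorophenyl in place of 3-chlorophenyl gives a 2.7-fold higher number from compound 1 to compound 4 (0.42 log units; beyond the scatter), while the same change on the other core gave no change at the digits printed from compound 2 to compound 3 (within the scatter). Set side by side, the two steps cannot be told apart: the same change on two cores in this assay, no change at the digits printed (within the scatter) from compound 2 to compound 3 and a 2.7-fold higher number (0.42 log units; beyond the scatter) from compound 1 to compound 4, 2.7-fold (0.42 log units) apart, within the scatter of two such steps. This gives no sign that the change behaves differently on the two cores, but it does not show that it carries over unchanged, and two pairs cannot fix the size of the step on a further core.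

The compounds shown leave open whether the same holds with an amine or a carboxylic acid in place of the methoxy groups. They also leave open how a fluorine in place of the chlorine would behave.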